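Amide-nitrogen group swap from compound 2 to compound 3

The source may report more compounds than this note shows. Statements on the series, on what has been measured and on what is new or still open speak of the compounds shown alone.

Values in an ADME assay on HEp-2 cells (Homo sapiens) for cytotoxicity; a lower number here means that less compound is tolerated, a higher number that more compound is tolerated:
- compound 1 `Cc1ccc(NC(=O)[C@@H]2CCCN2S(=O)(=O)c2cccc3cccnc23)cc1`: 31700 nM
- compound 2 `O=C(Nc1ccc(Cl)cc1Cl)[C@@H]1CCCN1S(=O)(=O)c1cccc2cccnc12`: > 50000 nM
- compound 3 `Cc1cccc(C)c1NC(=O)[C@@H]1CCCN1S(=O)(=O)c1cccc2cccnc12`: not yet measured

Compound 2 gives > 50000 nM, which is a limit and not a number. Compound 3 differs from it by 2,6-dimethylphenyl in place of 2,4-dichlorophenyl on an amide-type nitrogen. Going by the values given here, one measured step bears on this change, an at least 1.5-fold higher number from compound 1 to compound 2 (0.19 log units; that floor lies within the scatter). Among the compounds with values here, it changes the same place, and compound 1, at 31700 nM, gives the only actual number. In this assay, a small move to a lower number or none beyond the scatter is therefore expected. The expected change is an at least 1.2-fold lower number from compound 2 to compound 3 (0.09 log units; that floor lies within the scatter). For compound 3 the estimated value is 40000 nM, with an expected range of 18000 nM to 50000 nM.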

Compound 3, half-maximal cytotoxic concentration: > 50000 nM
Compound 3: only a limit was reported; the forecaster's own chance of this, stated with the estimate: 40%; middle value at least 1.2-fold (0.09 log units) away from the limit.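

In this assay compound 3 gives > 50000 nM, which is a limit and not a number. Going by these compounds alone, with two limits, the step between compound 2 and compound 3 cannot be read, so 2,6-dimethylphenyl and 2,4-dichlorophenyl on the amide-type nitrogen stay unranked, and the one readable new step is an at least 1.5-fold higher number from compound 1 to compound 3 (0.19 log units; that floor lies within the scatter). A group of carbon only at this place thus reaches the same limit as the chlorine-bearing group: the limit of > 50000 nM in this assay, at which 2 of the 3 values shown sit.

As far as these compounds go, the actual values of compound 2 and compound 3 remain open. Also open, from the compounds shown here alone, is how a carboxylic acid or an amine in place of the phenyl group on this nitrogen would read.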